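Carboxy in place of hydroxymethyl on the oxime ether chain

The compounds below may be only part of what the source reports. "The series", "measured", "known", "first", "only" and "open" are said of these compounds alone.

Compound 1, `C/C(=N\OCC(=O)O)c1ccc(C)cc1`: 20%
Compound 2, `CCCCC/C(=N\OCC(=O)O)c1ccc(Cl)cc1`: < 20%
Compound 3, `C/C(=N/OCCO)c1ccc(Cl)s1`: < 20%

In a functional assay on the whole organism for inhibition, with Rattus norvegicus as the target, read by paw edema, with stated times of 1 h and 3 h, at a dose of 50 mg/kg by the oral route (on this read-out lower numbers stand for less inhibition and higher numbers for more inhibition at the one dose given (going by the name of the read-out)), compound 1 gives 20%. For compound 2 the value < 20% is a limit of this assay, not a number. Compound 3 also sits at a limit, < 20%, the same limit at which most of the shown values stand (the limit of < 20% in this assay, at which 2 of the 3 values shown sit). Among the measured compounds shown here, no step between measured compounds is known here. Compound 4, `C/C(=N/OCC(=O)O)c1ccc(Cl)s1`, differs from compound 3 by carboxy in place of hydroxymethyl on a saturated chain carbon bound to an oxygen. Compound 1 and compound 2 already carry the carboxymethyl chain of compound 4, and both sit at the low end of the read-out. The step of a number no lower from compound 3 to compound 4 (the limit leaves the size open) is therefore expected to stay within the usual scatter, with no clear direction. For compound 4 an inhibition of 20% is estimated, within 5% to 35%.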

Compound 4, a percentage reported as inhibition, in the whole organism at one dose (the size of the read-out at that dose, not a potency): < 20%
Compound 4: a limit, no number; the forecaster's own chance of this, stated with the estimate: 50%; the middle value sits exactly at the limit.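

No step from compound 3 to compound 4 can be read in this assay, because both stand at a limit: the limit of < 20% in this assay, at which 3 of the 4 values shown sit.

The compounds shown leave open whether carboxy in place of hydroxymethyl changes the inhibition at all.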